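Nitro-to-hydroxy change on two chromone cores, cytotoxicity notes

This account rests on a few compounds, and the source may have more. Where it says the series, first, only, none or still open, it means among the compounds named here.

Compound 1, `COC(=O)c1c(-c2ccc([N+](=O)[O-])cc2)oc2cc(OC)ccc2c1=O`, is the reference point of the set. In a functional assay on SK-MEL cells (Homo sapiens) for cytotoxicity, read by MTT assay, with a stated time of 6 days (a lower number here means that less compound is needed, a higher number that more compound is needed for the effect), compound 1 gives 2.84 ug/mL. Compound 2, `COC(=O)c1c(-c2ccc(O)cc2)oc2cc(OC)ccc2c1=O`, carries the change hydroxy in place of nitro on an aromatic carbon and otherwise shares the core of compound 1. In this assay compound 2 gives 19.6 ug/mL, so the measured step is a 6.9-fold higher number from compound 1 to compound 2 (0.84 log units; beyond the scatter), which means more compound is needed after the change.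

Compound 3, `COc1ccc2oc(-c3ccc([N+](=O)[O-])cc3)c(C(=O)O)c(=O)c2c1`, keeps the nitro group but differs from compound 1 in its core; how the two cores differ is not broken down here. For compound 3 the result in this assay is a limit of the assay and not a number, namely > 25 ug/mL, and this is the limit of > 25 ug/mL in this assay, at which 1 of the 3 values shown sits.

Compound 4, `COc1ccc2oc(-c3ccc(O)cc3)c(C(=O)O)c(=O)c2c1`, is not yet measured. It stands to compound 3 as compound 2 stands to compound 1: the change is hydroxy in place of nitro on an aromatic carbon, and the two place descriptions agree word for word, so it is the same change made on a different core.

Going by the values given here, the only measured instance of this change, a 6.9-fold higher number from compound 1 to compound 2 (0.84 log units; beyond the scatter), points to a higher number. Compound 3 already sits at the limit, so compound 4 is expected to need at least as much compound, with an expected step that the limit leaves unreadable from compound 3 to compound 4. The expected value for compound 4 in this assay is therefore 100 ug/mL, estimated between 25 ug/mL and 400 ug/mL, and most likely the assay will again report only a limit.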

Compound 4, concentration for half-maximal effect: > 25 ug/mL
Compound 4: only a limit was reported; the forecaster's own chance of this, stated with the estimate: 90%; the middle value is on the limit's open side.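

In this assay, compound 3 and compound 4 both end at a limit of the assay and not at a number, so the step between them cannot be read: the limit of > 25 ug/mL in this assay, at which 2 of the 4 values shown sit.

The compounds shown leave open whether hydroxy in place of nitro on an aromatic carbon changes the number on the core of compound 3, and how far beyond the limit either compound lies.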